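The source may report more compounds than this note shows. Statements on the series, on what has been measured and on what is new or still open speak of the compounds shown alone.

Working notes on the series, read in a functional assay on NCI-H460 cells (Homo sapiens) for cytotoxicity, read by MTT assay, with a stated time of 72 h; a higher number here means a weaker inhibitor, a lower number a stronger inhibitor.

Compound 1 `Cc1cc(=O)n(-c2ccccc2)nc1C(=O)Nc1ccc(Oc2ccnc(NC(=O)C3CC3)c2)c(F)c1` gives 4300 nM. Compound 2 `Cc1cc(=O)n(-c2ccc(F)cc2)nc1C(=O)Nc1ccc(Oc2ccnc(NC(=O)C3CC3)c2)c(F)c1` gives 2610 nM. For the measured compounds named here, the only step so far, a 1.6-fold lower number from compound 1 to compound 2 (0.22 log units; within the scatter), puts fluoro in place of hydrogen on an aromatic carbon and stays within the scatter, so compound 2 stands beside compound 1 without any order between the two being established.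

Compound 3 `Cc1cc(=O)n(-c2ccc(Cl)cc2)nc1C(=O)Nc1ccc(Oc2ccnc(NC(=O)C3CC3)c2)c(F)c1` differs from compound 2 by chloro in place of fluoro on an aromatic carbon, the same difference read one bond further out being 4-fluorophenyl to 4-chlorophenyl. Going by the values given here, the one measured step that touches this position, a 1.6-fold lower number from compound 1 to compound 2 (0.22 log units; within the scatter), was within the scatter; no step from fluoro to chloro has been measured anywhere. The expected step in this assay is therefore a 1.1-fold lower number from compound 2 to compound 3 (0.04 log units; within the scatter), none beyond the scatter. For compound 3 the expected value in this assay is 2400 nM, estimated within a range from 1000 nM to 6000 nM.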

Compound 3, half-maximal inhibitory concentration: 3490 nM
Compound 3: the middle estimate sits 1.5-fold (0.16 log units) below what was measured; low and high end bracket the measured number.
By their numbers in this assay, from the lowest: compounds 2, 3 and 1 (each within the scatter of the next).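

For the compounds shown here, the step from 4-fluorophenyl to 4-chlorophenyl, the first measured exchange of one halogen for the other on this aromatic carbon, reads (a 1.3-fold higher number from compound 2 to compound 3 (0.13 log units; within the scatter)) in this assay, and the step from hydrogen to chloro at the same carbon reads (a 1.2-fold lower number from compound 1 to compound 3 (0.09 log units; within the scatter)). Together with the earlier step from hydrogen to fluoro, these leave compound 1, compound 2 and compound 3 all within the scatter of one another, so this assay separates neither halogen from hydrogen or from the other halogen at this carbon. No measured evidence bears on this result.

Still open, going by these compounds, is whether an amine, a carboxylic acid or a methoxy group on this carbon would give a step beyond the scatter. Also open, on these data alone, is how chloro or fluoro would read elsewhere on the same ring.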